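A few compounds are considered here, and "the series" means these few. Any claim that something is new, unique, unknown or untested is made for them only; others in the source may bear on it.

Compound 1, `CCC(C)(C)Cc1c[nH]c(CCc2ccc(-c3ccncc3)cc2)n1`, in a functional assay on HEK293 cells for agonist activity at Bombesin receptor subtype-3 (Homo sapiens), read by luminescence and calcium flux, with a stated time of 10 min (a lower number here means that less compound is needed, a higher number that more compound is needed for the effect), gives 305 nM.
Compound 2, `CCC(C)(C)Cc1c[nH]c(CCc2ccc(-n3ccnn3)cc2)n1`, in this assay gives 641 nM.
Compound 3, `CCC(C)(C)Cc1c[nH]c(CCc2ccc(-c3cnccn3)cc2)n1`, in this assay gives 431 nM.

Among these three numbers compound 3 has the second highest, and it sits within the usual scatter of both neighbours: the step of a 1.4-fold higher number from compound 1 to compound 3 (0.15 log units; within the scatter) and the step of a 1.5-fold lower number from compound 2 to compound 3 (0.17 log units; within the scatter) are each too small to count as a real change. Among the measured compounds shown here, the only step that reaches beyond the scatter is a 2.1-fold higher number from compound 1 to compound 2 (0.32 log units; beyond the scatter), and even that one is modest.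

Compound 4, `CCC(C)(C)Cc1c[nH]c(CCc2ccc(-c3cccc(C#N)n3)cc2)n1`, arises from compound 3 by a single change: 6-cyanopyridin-2-yl in place of pyrazin-2-yl on an aromatic carbon. The group that enters is again a small six-membered aromatic heterocycle carrying two acceptors, as were all three groups tried so far at this position, which makes the three measured steps the closest guide. Because those swaps gave only a 1.4-fold higher number from compound 1 to compound 3 (0.15 log units; within the scatter) and a 1.5-fold lower number from compound 2 to compound 3 (0.17 log units; within the scatter), the step from compound 3 to compound 4 is expected to stay within the scatter in this assay, a 1.0-fold lower number from compound 3 to compound 4 (0.01 log units; within the scatter). Compound 4 is therefore estimated at 420 nM in this assay, with a likely range from 150 nM to 1200 nM.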

Compound 4, half-maximal effective concentration: 193 nM
Compound 4: the middle estimate sits 2.2-fold (0.34 log units) above what was measured; measured number inside the range.
By their numbers in this assay, from the lowest: compounds 4, 1, 3 and 2 (each within the scatter of the next, the first and the last beyond it).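

Among the compounds shown here, until now, only one step at this position, para to a large group, reached beyond the scatter. The 6-cyanopyridin-2-yl group adds two more, a 2.2-fold lower number from compound 3 to compound 4 (0.35 log units; beyond the scatter) and a 3.3-fold lower number from compound 2 to compound 4 (0.52 log units; beyond the scatter), the second being the largest step in this small set, though still modest. The step from pyrazin-2-yl also shows that the count of hydrogen-bond acceptors alone does not settle the number, since the group that leaves and the group that enters have the same count, while a 1.6-fold lower number from compound 1 to compound 4 (0.20 log units; within the scatter) means that the new group cannot be told apart from pyridin-4-yl in this assay.

From the compounds shown here alone, it remains open how a plain pyridin-2-yl, or a 6-aminopyridin-2-yl with an amine where the nitrile stands, would compare, and such a comparison would help separate the share of the nitrile from that of the ring carrying it. No measurement at hand explains why the number moves with this change.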